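The source may hold more compounds than are shown below. What is called first, only, known or untested is meant among the compounds shown, and "the series" means these compounds.

Measured in a functional assay on HCT-116 cells (Homo sapiens) for inhibition, read by luminescence and CellTiter-Glo, with a stated time of 72 h; a higher number here means a weaker inhibitor, a lower number a stronger inhibitor:
- Compound 1 `Cc1cc2c(NS(C)(=O)=O)cccc2n1-c1nc2c(c(NCc3cccc(O)c3)n1)CCC2`: 800 nM
- Compound 2 `C=CC(=O)Nc1cccc2c1cc(C)n2-c1nc2c(c(NCc3cccc(O)c3)n1)CCC2`: 1200 nM

Within the data shown here, compound 2 stands within the scatter of the only other measured value, as a 1.5-fold higher number from compound 1 to compound 2 (0.18 log units; within the scatter) shows. Compound 3 `C/C=C/C(=O)Nc1cccc2c1cc(C)n2-c1nc2c(c(NCc3cccc(O)c3)n1)CCC2` carries prop-1-en-1-yl in place of vinyl on a carbonyl carbon. Among the measured compounds shown here, no measured step tests this change directly. The nearest evidence is a 1.5-fold higher number from compound 1 to compound 2 (0.18 log units; within the scatter), a swap of the group on the same nitrogen, so no shift beyond the scatter is expected in this assay. The expected step is a 1.1-fold higher number from compound 2 to compound 3 (0.03 log units; within the scatter). For compound 3 the estimate is 1300 nM, with an expected range of 600 nM to 3000 nM.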

Compound 3, half-maximal inhibitory concentration: 2400 nM
For compound 3 the middle estimate is 1.8-fold (0.27 log units) below the measured one, within the range that was stated.
By their numbers in this assay, from the lowest: compounds 1, 2 and 3 (each within the scatter of the next, the first and the last beyond it).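

In this assay, prop-1-en-1-yl on the carbonyl carbon in place of vinyl gives a step that stays at the edge of the scatter (a 2.0-fold higher number from compound 2 to compound 3 (0.30 log units; within the scatter)), so this change alone cannot be read as a real loss. Among these compounds, the group on the nitrogen does separate the compounds modestly for the first time (a 3.0-fold higher number from compound 1 to compound 3 (0.48 log units; beyond the scatter)), while the vinylcarbonyl step (a 1.5-fold higher number from compound 1 to compound 2 (0.18 log units; within the scatter)) stayed within the scatter. Nothing available explains these steps. Open, as far as these compounds go, is how a longer chain, or an amine, on the carbonyl carbon would read in this assay.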